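Replacing a Benzyl Sulfone by an Aryl Sulfone

The compounds below may be only part of what the source reports. "The series", "measured", "known", "first", "only" and "open" are said of these compounds alone.

Compound 1 `Cn1c(=O)c(S(=O)(=O)Cc2ccc(F)cc2)cc2cnc(Nc3ccc4[nH]ccc4c3)nc21`: 30000 nM
Compound 2 `Cn1c(=O)c(S(=O)(=O)c2ccc(F)cc2F)cc2cnc(Nc3ccc4c(c3)CC(=O)N4)nc21`: 15000 nM

In a functional assay on K562 cells (Homo sapiens) for inhibition, read by trypan blue exclusion, with a stated time of 72 h (a lower number here means a stronger inhibitor, a higher number a weaker inhibitor), compound 1 gives 30000 nM, the highest of the two numbers shown, while compound 2 gives 15000 nM, a difference that lies within the scatter. Compound 3 `Cc1ccc(S(=O)(=O)c2cc3cnc(Nc4ccc5[nH]ccc5c4)nc3n(C)c2=O)cc1` shares the core and the indole amine of compound 1 and differs only at the sulfonyl sulfur: 4-methylphenyl in place of 4-fluorobenzyl on a sulfonyl sulfur. Within the data shown here, no measured pair shows this change, so its effect is unknown. Since both measured compounds are weak, compound 3 is estimated to stay in the same weak range, with the step of a 1.5-fold lower number from compound 1 to compound 3 (0.18 log units; within the scatter) expected to be no larger than the scatter. Compound 3 is thus expected to give about 20000 nM, between 5000 nM and 80000 nM.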

Compound 3, half-maximal inhibitory concentration: 750 nM
Compound 3: middle estimate off by 27-fold (1.43 log units), on the high side, outside the stated range (below it).
By their numbers in this assay, from the lowest: compound 3; then compounds 2 and 1 (each within the scatter of the next).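

In this assay the group on the sulfonyl sulfur proves to matter: 4-methylphenyl in place of 4-fluorobenzyl gives (a 40-fold lower number from compound 1 to compound 3 (1.60 log units; beyond the scatter)), with the rest of compound 1 unchanged. Among these compounds, this is the first step here that isolates this position, and it lies beyond the scatter. No measurement shown accounts for its size. On these data alone, the change alters both the benzyl link and the ring substituent, so which part carries the step remains open. A 4-fluorophenyl or 4-methylbenzyl group on the sulfonyl sulfur would separate the two.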